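The source may report more compounds than this note shows. Statements on the series, on what has been measured and on what is new or still open speak of the compounds shown alone.

Measured compounds:
Compound 1, `Cc1cc(C)c(-n2c(Cl)cn3c(CN(CCC(F)(F)F)CC4CC4)c(C(F)(F)F)nc23)c(C)c1`: 16 nM
Compound 2, `CCCN(CCC(F)(F)F)Cc1c(C(F)(F)F)nc2n(-c3c(C)cc(C)cc3C)c(Cl)cn12`: 12 nM
Compound 3, `CCN(CCC1CC1)Cc1c(C(F)(F)F)nc2n(-c3c(C)cc(C)cc3C)c(Cl)cn12`: 13 nM

All three share one core and differ only in the amine that hangs from it. In an assay on cells for displacement of a labelled ligand from corticotropin-releasing factor receptor 1 (Homo sapiens), with a stated time of 100 min (a lower number here means a stronger inhibitor, a higher number a weaker inhibitor), compound 3 gives 13 nM, the second highest of the three numbers; compound 2 gives 12 nM and compound 1 gives 16 nM, and the steps between them are all within the scatter, as a 1.3-fold lower number from compound 1 to compound 2 (0.12 log units; within the scatter) and a 1.2-fold lower number from compound 1 to compound 3 (0.09 log units; within the scatter) show.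

Compound 4, `Cc1cc(C)c(-n2c(Cl)cn3c(CN(CCC4CC4)CCC(F)(F)F)c(C(F)(F)F)nc23)c(C)c1`, is compound 3 with one change: trifluoromethyl in place of hydrogen on a saturated chain carbon, two bonds along the chain from an amine nitrogen. The step that bears most directly on it is a 1.1-fold higher number from compound 2 to compound 3 (0.03 log units; within the scatter), which swapped the whole amine and still stayed within the scatter, as did a 1.2-fold lower number from compound 1 to compound 3 (0.09 log units; within the scatter). Nothing seen so far suggests that trading one chain on this nitrogen for another shifts the number beyond the scatter, so compound 4 is expected to sit close to compound 3, with the estimated step of no change at the digits printed from compound 3 to compound 4 (within the scatter).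

The estimate for compound 4 in this assay is 13 nM, in a range of 6 nM to 28 nM.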

Compound 4, inhibition constant: 110 nM
Compound 4: the middle estimate sits 8.5-fold (0.93 log units) below what was measured; measured number above the stated range.
By their numbers in this assay, from the lowest: compounds 2, 3 and 1 (each within the scatter of the next); then compound 4.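

Until now the amine on the shared core had taken changes of its chains without moving the number beyond the scatter, but in this assay the chain change here gives an 8.5-fold higher number from compound 3 to compound 4 (0.93 log units; beyond the scatter) when trifluoromethyl replaces hydrogen, turning ethyl into 3,3,3-trifluoropropyl. The other neighbours agree, with a 9.2-fold higher number from compound 2 to compound 4 (0.96 log units; beyond the scatter) for cyclopropyl in place of methyl and a 6.9-fold higher number from compound 1 to compound 4 (0.84 log units; beyond the scatter) for cyclopropylmethyl in place of cyclopropyl, so among these four compounds the number climbs only where 3,3,3-trifluoropropyl and 2-cyclopropylethyl share the nitrogen. No measurement here gives a reason for this jump.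

A plain propyl chain in place of 3,3,3-trifluoropropyl in compound 4 would show whether the fluorine atoms or the chain length matter here. As far as these compounds go, how a 2,2,2-trifluoroethyl chain on the same nitrogen would fare also remains open.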